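The source may report more compounds than this note shows. Statements on the series, on what has been measured and on what is new or still open speak of the compounds shown alone.

Of the compounds shown here, two have so far been measured in a functional assay on HEK293 cells for antagonist activity at Orexin receptor type 2 (Homo sapiens), read by FLIPR and calcium flux; a lower number here means a less potent compound, a higher number a more potent compound, by a factor of ten per unit of this negative logarithm. Compound 1 `Cc1cnn(-c2ccc(C)nc2C(=O)N2CC3(CC3)C[C@H]2CNc2ccc(C(F)(F)F)cn2)c1` gives 8.3 in this assay, and compound 2 `Cc1cc(C(F)(F)F)cc(NC[C@@H]2CC3(CC3)CN2C(=O)c2nc(C)sc2-c2ccccc2)n1` gives 8.6. Compound 2 shows the higher of the two numbers, but its distance from compound 1 lies within the usual scatter, so the two cannot be ranked against each other. Compound 3 `Cc1nc(C(=O)N2CC3(CC3)C[C@H]2CNc2ccc(C(F)(F)F)cn2)c(-c2ccccc2)s1` keeps the core of compound 2 and differs from it in one place: 5-(trifluoromethyl)pyridin-2-yl in place of 6-methyl-4-(trifluoromethyl)pyridin-2-yl on an amine nitrogen. The group that enters is the same one that compound 1 carries on its amine nitrogen, and compound 1 gives 8.3 in this assay, so no step beyond the scatter is expected in either direction. Compound 3 is therefore expected to give 8.4, with a range from 7.8 to 9. The step that this estimate implies, a number 0.20 log units lower from compound 2 to compound 3 (within the scatter), is expected to be a small one.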

Compound 3, negative logarithm of the antagonist equilibrium constant: 7.7
For compound 3 the middle estimate is 0.70 log units above the measured one; measured number outside the range, below it.
By their numbers in this assay, from the lowest: compound 3; then compounds 1 and 2 (each within the scatter of the next).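

In this assay, placing 5-(trifluoromethyl)pyridin-2-yl on the amine nitrogen instead of 6-methyl-4-(trifluoromethyl)pyridin-2-yl gives a number 0.90 log units lower from compound 2 to compound 3 (beyond the scatter), so on this core the two groups are not interchangeable at that nitrogen. Compounds 1 and 2 could not show this, as they differ in more than one place and their numbers lie within the scatter of each other. The two groups differ in the methyl and in where the trifluoromethyl sits, and nothing measured here explains the drop. No compound shown changes only one of these two features, so it stays open which of them carries the step. Going by these compounds, it is also open how a pyridin-2-yl group bearing a methoxy group or an amine instead of the trifluoromethyl would read at this nitrogen.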